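From tert-butyl to isopentyloxy: a small expected step

This account rests on a few compounds, and the source may have more. Where it says the series, first, only, none or still open, it means among the compounds named here.

Compound 1 `CCCCOc1ccc(-c2c(C)[nH]c(=O)n2C)cc1` gives 5100 nM
Compound 2 `Cc1[nH]c(=O)n(C)c1-c1ccc(C(C)(C)C)cc1` gives 8400 nM

Both numbers come from a functional assay on brain (Rattus norvegicus, strain Wistar) for inhibition (a lower number here means a stronger inhibitor, a higher number a weaker inhibitor), and lie within the usual scatter of each other. Compound 2 at 8400 nM therefore shares its place with compound 1 and does not stand apart from it. Compound 3 `Cc1[nH]c(=O)n(C)c1-c1ccc(OCCC(C)C)cc1` keeps the shared core and carries isopentyloxy in place of tert-butyl on an aromatic carbon. Going by the values given here, one measured step bears on this change. It is a 1.6-fold higher number from compound 1 to compound 2 (0.22 log units; within the scatter) and it swaps the same kind of group in the opposite direction, from butoxy to tert-butyl. Compound 3 returns to a chain joined through oxygen, as in compound 1 at 5100 nM in this assay and so a return to that same level seems the natural expectation. Among the compounds with values here, two compounds are thin evidence, and the data hold no isopentyloxy example. No step beyond the scatter is expected. The estimate is a 1.7-fold lower number from compound 2 to compound 3 (0.23 log units; within the scatter) in plain terms of expectation. For compound 3 the estimated value is 5000 nM with an expected range from 2000 nM to 12000 nM across repeat measurements.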

Compound 3, half-maximal inhibitory concentration: 6600 nM
For compound 3 the middle estimate is 1.3-fold (0.12 log units) below the measured one, and the stated range covers the measured number.
By their numbers in this assay, from the lowest: compounds 1, 3 and 2 (each within the scatter of the next).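

In this assay the swap of tert-butyl for isopentyloxy gives a 1.3-fold lower number from compound 2 to compound 3 (0.10 log units; within the scatter) and so stays within the scatter, which means that for these compounds a group joined through oxygen and a group joined directly through carbon cannot be told apart on this aromatic carbon. The other new comparison adds a single methyl in place of hydrogen on a saturated chain carbon, turning butoxy into the branched isopentyloxy, and a 1.3-fold higher number from compound 1 to compound 3 (0.11 log units; within the scatter) shows that this branching also leaves the number within the scatter. The three groups therefore sit at one shared level in this assay, and nothing measured alongside these numbers offers an explanation for that.

Still open, as far as these compounds go, is whether any group on this aromatic carbon can move the number beyond the scatter, and an amine, a carboxylic acid or a much longer chain would be informative tests of that. Also open, from the compounds shown here alone, is how the number responds to changes elsewhere on the shared core, since all three compounds keep it unchanged.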